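Tetrazolylmethyl in place of thiazolylamino on the shared core

The compounds below may be only part of what the source reports. "The series", "measured", "known", "first", "only" and "open" are said of these compounds alone.

Measured compounds:
compound 1 `CC(C)C(c1nnc[nH]1)c1ccc(-c2ccc3cccc(F)c3c2)[nH]c1=O` gives 12 nM
compound 2 `CC(C)C(Nc1nccs1)c1ccc(-c2ccc3cccc(F)c3c2)[nH]c1=O` gives 9.4 nM

Both numbers come from an assay on CHO cells for displacement of a labelled ligand from prostaglandin E2 receptor EP3 subtype (Homo sapiens), read by radioligand binding; on this read-out higher numbers stand for weaker inhibition and lower numbers for stronger inhibition. On this scale compound 2 and compound 1 cannot be told apart: a 1.3-fold lower number from compound 1 to compound 2 (0.11 log units; within the scatter), so compound 2 stands together with compound 1 rather than apart from it. Compound 3 `CC(C)C(Cc1nnn[nH]1)c1ccc(-c2ccc3cccc(F)c3c2)[nH]c1=O` is not yet measured. It differs from compound 2 in one place: (1H-tetrazol-5-yl)methyl in place of (1,3-thiazol-2-yl)amino on a saturated chain carbon bound to an aromatic carbon and a saturated chain carbon. For the measured compounds named here, only one measured step bears on this change, a 1.3-fold lower number from compound 1 to compound 2 (0.11 log units; within the scatter), an exchange of one five-membered ring group for another at the same chain carbon, and it stayed within the scatter. Neither measured compound carries a tetrazole or the added chain carbon. Because a 1.3-fold lower number from compound 1 to compound 2 (0.11 log units; within the scatter) stayed within the scatter, compound 3 is expected to move little, a 2.1-fold higher number from compound 2 to compound 3 (0.33 log units; beyond the scatter). Going by the values given here, the estimate for compound 3 in this assay is 20 nM, with a range from 5 nM to 80 nM; the range is wide, as no measured step covers the new group.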

Compound 3, inhibition constant: 34 nM
The estimate for compound 3 lay 1.7-fold (0.23 log units) below the measured number; measured number inside the range.
By their numbers in this assay, from the lowest: compounds 2 and 1 (each within the scatter of the next); then compound 3.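

In this assay the chain carbon proved less tolerant than the earlier pair suggested: the step of a 3.6-fold higher number from compound 2 to compound 3 (0.56 log units; beyond the scatter) and the step of a 2.8-fold higher number from compound 1 to compound 3 (0.45 log units; beyond the scatter) both lie beyond the scatter, though still modest, whereas the exchange between compound 1 and compound 2 did not. The (1H-tetrazol-5-yl)methyl and (1,3-thiazol-2-yl)amino groups have equal counts of heavy atoms, hydrogen-bond donors and hydrogen-bond acceptors and carry no net charge, so these counts do not separate the better from the poorer number here. No measurement at hand explains the loss.

The compounds shown leave open whether the step follows the tetrazole ring or its methyl link. A 1H-tetrazol-5-yl group or a (1,3-thiazol-2-yl)methyl group on the same chain carbon would separate the two, and a carboxylic acid there remains untested in what is shown.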